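The source may hold more compounds than are shown below. What is called first, only, known or untested is meant among the compounds shown, and "the series" means these compounds.

Compound 1, `CCCCC1NC(=O)NC(C)=C1C(=O)OC`: in an assay for inhibition of beta-glucuronidase (Bos taurus), read by spectrophotometry, with a stated time of 30 min (on this read-out higher numbers stand for weaker inhibition and lower numbers for stronger inhibition), compound 1 gives 78200 nM.
Compound 2, `COC(=O)C1=C(C)NC(=O)NC1c1ccc(Cl)cc1`: in this assay compound 2 gives 34200 nM.

Of these two numbers, compound 2 has the lower one; the number for compound 1 is higher, and the gap between them is beyond the usual scatter. Compound 3, `COC(=O)C1=C(C)NC(=O)NC1c1ccc(N(C)C)cc1`, differs from compound 2 in one place: dimethylamino in place of chloro on an aromatic carbon. For the measured compounds named here, no pair of measured compounds shows what this kind of change does, so the expected step of a 1.0-fold higher number from compound 2 to compound 3 (0.01 log units; within the scatter) is small, within the scatter, with no clear direction. Compound 3 is therefore expected to give 35000 nM, with a range from 12000 nM to 100000 nM.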

Compound 3, half-maximal inhibitory concentration: 49200 nM
The estimate for compound 3 lay 1.4-fold (0.15 log units) below the measured number; the measured number falls inside the stated range.
By their numbers in this assay, from the lowest: compounds 2, 3 and 1 (each within the scatter of the next, the first and the last beyond it).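

Dimethylamino in place of chloro on this aromatic carbon gives a 1.4-fold higher number from compound 2 to compound 3 (0.16 log units; within the scatter) in this assay and stays within the scatter. At this place, para to a large group, this read-out therefore does not separate the two groups, even though dimethylamino has more heavy atoms and a hydrogen-bond acceptor that chloro lacks. No other measurement bears on this result. As far as these compounds go, what a carboxylic acid or a primary amine would do on this same aromatic carbon stays open. So does whether dimethylamino in place of chloro gives a similar step on a different core.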